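Trading a Side-Chain Alkene for an Enone

A few compounds are considered here, and "the series" means these few. Any claim that something is new, unique, unknown or untested is made for them only; others in the source may bear on it.

Two compounds share the same long conjugated core and the same cyclic ether attached to it; they differ only in how that ring is arranged. Compound 1 `COc1cc(/C=C/C(=O)/C=C(O)/C=C/c2ccc(O[C@H]3C[C@H]([C@@H](C)CCC=C(C)C)C=C[C@@]3(C)O)c(OC)c2)ccc1O` and compound 2 `COc1cc(/C=C/C(=O)/C=C(O)/C=C/c2ccc(O[C@]3(C)C=C[C@@H]([C@@H](C)CCC=C(C)C)C[C@@H]3O)c(OC)c2)ccc1O` have both been tested in a functional assay on MDA-MB-231 cells (Homo sapiens) for cytotoxicity, read by crystal violet staining, with a stated time of 72 h; a higher number here means a weaker inhibitor, a lower number a stronger inhibitor. Compound 1 gives 24600 nM. Compound 2 gives 84100 nM, the higher of the two numbers, and its gap to compound 1 lies beyond the scatter, so compound 2 is the weaker of the pair.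

Compound 3 `COc1cc(/C=C/C(=O)/C=C(O)/C=C/c2ccc(O[C@]3(C)C=C[C@@H]([C@@H](C)CC(=O)C=C(C)C)C[C@@H]3O)c(OC)c2)ccc1O` is not yet measured. It differs from compound 2 in one place: (2-methylprop-1-en-1-yl)carbonyl in place of 3-methylbut-2-en-1-yl on a saturated chain carbon, two bonds along the chain from a saturated ring carbon. The chain keeps its carbon count but gains one oxygen and one hydrogen-bond acceptor.

For the measured compounds named here, no measured pair shows this exchange, so its effect cannot be read from the numbers. Without such a reference, the step of a 1.5-fold lower number from compound 2 to compound 3 (0.18 log units; within the scatter) is expected to be modest, most likely toward a somewhat lower number, and possibly no larger than the scatter. On that basis compound 3 is expected to give about 55000 nM, with a range from 20000 nM to 150000 nM.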

Compound 3, half-maximal inhibitory concentration: 19400 nM
Beside the measured number, compound 3's estimate is 2.8-fold (0.45 log units) above it; the measured number lies below the stated range.
By their numbers in this assay, from the lowest: compounds 3 and 1 (each within the scatter of the next); then compound 2.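

In this assay, the end of the side chain proves to be a place where a change in structure shows up clearly: putting (2-methylprop-1-en-1-yl)carbonyl in place of 3-methylbut-2-en-1-yl gives a 4.3-fold lower number from compound 2 to compound 3 (0.64 log units; beyond the scatter), a step beyond the scatter. For the compounds shown here, the earlier pair differed only in how the ring was arranged, so this is the first sign that the chain, and not only the ring, affects the read-out. Nothing at hand explains this drop in the number.

The exchange adds a carbonyl and a second double bond in one move, so the compounds shown cannot say which of the two goes with the lower number; a saturated chain that keeps the carbonyl, or a hydroxyl group in the place of that carbonyl, would begin to separate them. Going by these compounds, it also remains open whether the same exchange would lower the number on the ring arrangement of compound 1, and whether a longer chain or an amine at this end of the chain would be tolerated.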